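A few compounds are considered here, and "the series" means these few. Any claim that something is new, unique, unknown or untested is made for them only; others in the source may bear on it.

Measured compounds in an assay on cells for inhibition of cytochrome P450 11B2, mitochondrial (Homo sapiens), read by HPLC, with a stated time of 90 min; a higher number here means a weaker inhibitor, a lower number a stronger inhibitor:
- compound 1 `Fc1ccc2nc(-c3cncnc3)n(C3CC3)c2c1`: 40 nM
- compound 2 `Fc1ccc2nc(-c3cccnn3)n(C3CC3)c2c1`: 412 nM
- compound 3 `Fc1cc2nc(-c3cncnc3)n(C3CC3)c2cc1F`: 22 nM

Compound 3 gives the lowest number of the three in this assay. The nearest is compound 1, a 1.8-fold lower number from compound 1 to compound 3 (0.26 log units; within the scatter), so the two cannot be told apart. Going by the values given here, the furthest is compound 2, whose number stands well beyond the scatter from compound 3; the one measured step that produces a change of that size, a 10-fold higher number from compound 1 to compound 2 (1.01 log units; beyond the scatter), exchanges the whole six-membered ring rather than decorating it.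

Compound 4 `Fc1cc2nc(-c3cncnc3C3CC3)n(C3CC3)c2cc1F` keeps the core of compound 3 and differs only at one point: cyclopropyl in place of hydrogen on an aromatic carbon. Neither measured step bears directly on this change. The step from compound 1 to compound 3 concerns the core; the step from compound 1 to compound 2 concerns the identity of the attached ring, not a substituent on it. There is therefore no measured precedent for adding a group at this position, and the expectation rests on the absence of any large effect being shown for small additions.

The expected step, a 1.4-fold higher number from compound 3 to compound 4 (0.13 log units; within the scatter), is set at no change beyond the scatter but with a wide range. Compound 4 is estimated at 30 nM, between 6 nM and 150 nM.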

Compound 4, half-maximal inhibitory concentration: 172 nM
The estimate for compound 4 lay 5.7-fold (0.76 log units) below the measured number; the whole stated range lies below it.
By their numbers in this assay, from the lowest: compounds 3 and 1 (each within the scatter of the next); then compound 4; then compound 2.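

In this assay, the position on an aromatic carbon of the six-membered aromatic ring with 2 nitrogen, next to the ring nitrogen and ortho to a large group, proves sensitive to substitution: cyclopropyl in place of hydrogen gives a 7.8-fold higher number from compound 3 to compound 4 (0.89 log units; beyond the scatter) on the core of compound 3. Going by these compounds alone, this is the only measured step that adds a substituent to the attached ring, whereas the earlier steps altered the core or exchanged the ring itself. No measurement available here accounts for the rise in the number.

From the compounds shown here alone, whether this step is particular to cyclopropyl stays open, since a methyl, a methoxy, an amine or a longer chain at the same carbon would each test that. Going by these compounds, it is also open whether cyclopropyl gives a step of similar size on the core of compound 1.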